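Cyclopropylmethyl for nitrobenzyl on the thioether arm

This account rests on a few compounds, and the source may have more. Where it says the series, first, only, none or still open, it means among the compounds named here.

Measured compounds:
compound 1 `Cc1cc(Nc2cc(-c3ccccc3)[nH]n2)n2nc(SCc3ccc([N+](=O)[O-])cc3)nc2n1`: 4250 nM
compound 2 `Cc1cc(Nc2ccn(Cc3nc(C)c4ccccc4n3)n2)n2nc(SCc3ccc(Br)cc3)nc2n1`: 960 nM
compound 3 `COc1ccc(Cn2ccc(Nc3cc(C)nc4nc(SCc5ccc(Br)cc5)nn34)n2)cc1`: 12600 nM

In a functional assay on MGC-803 cells (Homo sapiens) for inhibition, read by MTT assay, with a stated time of 72 h (a lower number here means a stronger inhibitor, a higher number a weaker inhibitor), compound 1 gives 4250 nM, the second highest of the three numbers; compound 3 sits nearer to it, compound 2 furthest, both gaps beyond the scatter. Among the measured compounds shown here, the only step between two measured compounds, a 13-fold higher number from compound 2 to compound 3 (1.12 log units; beyond the scatter), concerns the group on the saturated chain carbon bound to an aromatic nitrogen, a site that compound 1 and compound 4 share unchanged, so it offers no direct guidance for the present change.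

Compound 4 `Cc1cc(Nc2cc(-c3ccccc3)[nH]n2)n2nc(SCC3CC3)nc2n1` differs from compound 1 in cyclopropyl in place of 4-nitrophenyl on a saturated chain carbon bound to a sulfur. For the measured compounds named here, compounds 2 and 3 both carry 4-bromophenyl at this position and give no read on a small non-aromatic ring there; no measured pair varies the group on the saturated chain carbon bound to a sulfur. The expectation for compound 4 is therefore uncertain, with a modest weakening considered somewhat more likely than a gain, as a 1.6-fold higher number from compound 1 to compound 4 (0.22 log units; within the scatter). Compound 4 is estimated at 7000 nM, within 2000 nM to 25000 nM.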

Compound 4, half-maximal inhibitory concentration: 16100 nM
Estimate against measurement, compound 4: 2.3-fold (0.36 log units) below, within the range that was stated.
By their numbers in this assay, from the lowest: compound 2; then compound 1; then compounds 3 and 4 (each within the scatter of the next).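

In this assay the group on the saturated chain carbon bound to a sulfur now has its first direct read: a 3.8-fold higher number from compound 1 to compound 4 (0.58 log units; beyond the scatter), so on the core of compound 1 this position does not tolerate cyclopropyl in place of 4-nitrophenyl without loss. The change takes out 9 heavy atoms, an aromatic ring and 2 hydrogen-bond acceptors and puts in 3 heavy atoms in a three-membered ring with no acceptors, so these differences travel together in this single pair. No available measurement accounts for the step.

Still open, as far as these compounds go, is which part of 4-nitrophenyl carries the difference. Unsubstituted phenyl at this place would test the aromatic ring without the nitro group, and cyclohexyl would test a larger non-aromatic ring.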